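Sulfonyl Aryl Variation in 5-Hydroxytryptamine Receptor 4 Ligands

A few compounds are considered here, and "the series" means these few. Any claim that something is new, unique, unknown or untested is made for them only; others in the source may bear on it.

Compound 1 `COc1ccc(S(=O)(=O)NCCN2CCC(CCC(=O)c3cc(Cl)c(N)cc3OC)CC2)cc1Cl`: 22.5 nM
Compound 2 `COc1cc(N)c(Cl)cc1C(=O)CCC1CCN(CCNS(=O)(=O)c2ccc3c(c2)NC(=O)CO3)CC1`: 6.2 nM
Compound 3 `COc1ccc(S(=O)(=O)NCCN2CCC(CCC(=O)c3cc(Cl)c(N)cc3OC)CC2)c(OC)c1`: 18.7 nM

In an assay on brain for displacement of a labelled ligand from 5-hydroxytryptamine receptor 4 (Cavia porcellus), with a stated time of 30 min, in the presence of a further agent that is not named here (on this read-out higher numbers stand for weaker inhibition and lower numbers for stronger inhibition), compound 2 gives the lowest number of the three; compound 3 sits a 3.0-fold higher number from compound 2 to compound 3 (0.48 log units; beyond the scatter) and compound 1 lies a 3.6-fold lower number from compound 1 to compound 2 (0.56 log units; beyond the scatter) away. Compound 4 `COc1cc(N)c(Cl)cc1C(=O)CCC1CCN(CCNS(=O)(=O)c2cc(Br)c(N)c(Br)c2)CC1` differs from compound 2 by a group of 9 heavy atoms (6 carbon, 1 nitrogen, 2 bromine; one six-membered aromatic ring of carbon only) in place of a group of 11 heavy atoms (8 carbon, 1 nitrogen, 2 oxygen; one six-membered non-aromatic ring with 2 hetero atoms, one six-membered aromatic ring of carbon only), on a sulfonyl sulfur. Among the measured compounds shown here, the steps that bear on this are a 3.6-fold lower number from compound 1 to compound 2 (0.56 log units; beyond the scatter) and a 3.0-fold higher number from compound 2 to compound 3 (0.48 log units; beyond the scatter), both modest and both pointing to higher numbers when the bicyclic group on the sulfonyl sulfur is exchanged for a single aromatic ring. The step of a 1.2-fold lower number from compound 1 to compound 3 (0.08 log units; within the scatter) shows that the choice of substituents on that single ring mattered little between those two compounds. A modest rise is therefore expected, a 2.9-fold higher number from compound 2 to compound 4 (0.46 log units; beyond the scatter). Compound 4 is estimated at 18 nM, within 7 nM to 45 nM.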

Compound 4, inhibition constant: 8.7 nM
Beside the measured number, compound 4's estimate is 2.1-fold (0.32 log units) above it, within the range that was stated.
By their numbers in this assay, from the lowest: compounds 2 and 4 (each within the scatter of the next); then compounds 3 and 1 (each within the scatter of the next).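

With 4-amino-3,5-dibromophenyl on the sulfonyl sulfur, a single aromatic ring stays within the scatter of the group it replaces in this assay, at a 1.4-fold higher number from compound 2 to compound 4 (0.15 log units; within the scatter) and so the second ring of that group is not needed for a number of this size. This single ring also parts from the other two, with a 2.1-fold lower number from compound 3 to compound 4 (0.33 log units; beyond the scatter) and with a 2.6-fold lower number from compound 1 to compound 4 (0.41 log units; beyond the scatter) and so the substituents on a single ring can matter at this position. No measurement shown accounts for this.

Going by these compounds, whether the amine or the two bromine atoms carry the gap stays open; 4-aminophenyl and 3,5-dibromophenyl on the sulfonyl sulfur would separate them.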